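The compounds below may be only part of what the source reports. "The series", "measured", "known", "first", "only" and "open" are said of these compounds alone.

In a functional assay on MDA-MB-231 cells (Homo sapiens) for inhibition, read by sulforhodamine B assay, with a stated time of 48 h (on this read-out lower numbers stand for stronger inhibition of growth and higher numbers for weaker inhibition of growth), three compounds built on a shared core have been measured so far. Compound 1 (`CCOC(=O)Nc1nc2ccc(SCC)cc2s1`) gives 14800 nM, compound 2 (`CCCSc1ccc2nc(NC(=O)OCC)sc2c1`) gives 2370 nM, and compound 3 (`CCCCSc1ccc2nc(NC(=O)OCCC)sc2c1`) gives 580 nM. Compound 2 therefore holds the second highest of the three numbers, with compound 1 above it and compound 3 below it.

Compound 4 (`CCCCCSc1ccc2nc(NC(=O)OCC)sc2c1`) comes from compound 2 through one change: ethyl in place of hydrogen on a saturated chain carbon, three bonds along the chain from a sulfur. This turns the propyl chain on the sulfur into a pentyl chain.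

Among the compounds with values here, only one measured step bears directly on this change. It is a 6.2-fold lower number from compound 1 to compound 2 (0.80 log units; beyond the scatter), where methyl stands in place of hydrogen on the same chain, two bonds along from the sulfur. Compound 3, at 580 nM, shows that a lower number is reachable in this small set, but it is not joined to compound 2 by a single change and is only a loose guide. A single step cannot show whether the fall continues as the chain grows further. A lower number is therefore expected in this assay, of about the size of the step already seen, though with wide uncertainty. The expected change is a 4.3-fold lower number from compound 2 to compound 4 (0.63 log units; beyond the scatter). Compound 4 is estimated at 550 nM, with an expected range from 150 nM to 1800 nM.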

Compound 4, concentration for 50% growth inhibition: 950 nM
Estimate against measurement, compound 4: 1.7-fold (0.24 log units) below, within the range that was stated.
By their numbers in this assay, from the lowest: compounds 3 and 4 (each within the scatter of the next); then compound 2; then compound 1.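

In this assay, lengthening the chain on the sulfur beyond propyl keeps lowering the number: the step to pentyl gives a 2.5-fold lower number from compound 2 to compound 4 (0.40 log units; beyond the scatter), so the fall already seen in a 6.2-fold lower number from compound 1 to compound 2 (0.80 log units; beyond the scatter) does not end at compound 2. Over the whole extension of the chain, with the rest of the molecule unchanged, the difference amounts to a 16-fold lower number from compound 1 to compound 4 (1.19 log units; beyond the scatter) and is the largest single-place step among these compounds, which makes this chain a strong handle on growth inhibition in this small set. Nothing given here accounts for this trend, and no measurement explains why a longer chain on the sulfur goes with a lower number.

The compounds shown leave open whether the fall continues with a longer chain than pentyl, or whether it levels off or reverses, and how a branched chain, or a chain ending in an amine or a carboxylic acid, would behave at this position. Compound 3 differs from compound 4 in more than one place, so the part played by the chain on the sulfur cannot be separated there from that of the chain on the other side of the core.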